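Carbonyl-to-thiocarbonyl swap beside a phenyl hydrazone

A few compounds are considered here, and "the series" means these few. Any claim that something is new, unique, unknown or untested is made for them only; others in the source may bear on it.

Three compounds share one core. Compound 1 `COc1ccc(/C=N/NC(=O)Nc2ccc(Oc3ccnc4cc(OCCCN5CCCCC5)c(OC)cc34)c(F)c2)cc1` gives 540 nM in a functional assay on A549 cells (Homo sapiens) for cytotoxicity, read by MTT assay, with a stated time of 72 h; a higher number here means a weaker inhibitor, a lower number a stronger inhibitor. Compound 2 `COc1cc2c(Oc3ccc(NC(=O)N/N=C/c4ccc(N(C)C)cc4)cc3F)ccnc2cc1OCCCN1CCCCC1` gives "not determined" (no result reported) in this assay, so no result is reported for it. Compound 3 `COc1cc2c(Oc3ccc(NC(=O)N/N=C/c4ccncc4)cc3F)ccnc2cc1OCCCN1CCCCC1` gives 840 nM in this assay, the highest of the two numbers, with compound 1 as its nearest neighbour; the two lie within the scatter of each other, as the step of a 1.6-fold higher number from compound 1 to compound 3 (0.19 log units; within the scatter) shows.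

Compound 4 `COc1cc2c(Oc3ccc(NC(=S)N/N=C/c4ccccc4)cc3F)ccnc2cc1OCCCN1CCCCC1` differs from compound 3 by a group of 11 heavy atoms (8 carbon, 2 nitrogen, 1 sulfur; one six-membered aromatic ring of carbon only) in place of a group of 11 heavy atoms (7 carbon, 3 nitrogen, 1 oxygen; one six-membered aromatic ring with 1 hetero atom), on a nitrogen on an aromatic ring. For the measured compounds named here, the only measured step that touches this change is a 1.6-fold higher number from compound 1 to compound 3 (0.19 log units; within the scatter), which swapped the aryl group on the carbon with a double bond to nitrogen and stayed within the scatter. Going by the values given here, no measured step addresses the exchange of oxygen for sulfur, so that part of the change is untested here. The expectation for compound 4 is therefore a step of a 1.3-fold lower number from compound 3 to compound 4 (0.11 log units; within the scatter) that stays close to compound 3, with wide uncertainty. Compound 4 is estimated at 650 nM, within a range from 200 nM to 2100 nM.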

Compound 4, half-maximal inhibitory concentration: 330 nM
The estimate for compound 4 lay 2.0-fold (0.29 log units) above the measured number; low and high end bracket the measured number.
By their numbers in this assay, from the lowest: compounds 4, 1 and 3 (each within the scatter of the next, the first and the last beyond it).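

In this assay, a 2.5-fold lower number from compound 3 to compound 4 (0.41 log units; beyond the scatter) lies beyond the scatter, whereas the aryl swap alone, a 1.6-fold higher number from compound 1 to compound 3 (0.19 log units; within the scatter), stayed within it, so this series does respond to structural change. The step carries two edits at once, a thiocarbonyl in place of the carbonyl and a phenyl ring of carbon only in place of pyridin-4-yl, and a single number cannot divide the effect between them. No measurement given here bears on why the number fell.

How much of the step belongs to the sulfur alone stays open, since the compounds shown include no carbonyl and thiocarbonyl pair carrying the same aryl group. Also open, from the compounds shown here alone, is how a carboxylic acid on the phenyl ring of compound 4 would read in this assay.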